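The source may report more compounds than this note shows. Statements on the series, on what has been measured and on what is new or still open speak of the compounds shown alone.

In a functional assay on CNE-2 cells (Homo sapiens) for inhibition, read by MTT assay, with a stated time of 72 h (on this read-out higher numbers stand for weaker inhibition and lower numbers for stronger inhibition), compound 3 `Nc1ncnc2c1c(-c1cnc3[nH]ccc3c1)nn2CCC(=O)NO` has only a limit, > 150000 nM. Compound 2 `Nc1ncnc2c1c(-c1cnc3[nH]ccc3c1)nn2CCCCCC(=O)NO` also has only a limit, > 50000 nM. Compound 1 `CNC(=O)CCCCCCCn1nc(-c2cnc3[nH]ccc3c2)c2c(N)ncnc21` gives a number, 8990 nM.

Compound 4 `Nc1ncnc2c1c(-c1cnc3[nH]ccc3c1)nn2CCCC(=O)NO` has (hydroxycarbamoyl)methyl in place of the hydroxycarbamoyl of compound 3, on a saturated chain carbon, two bonds along the chain from an aromatic nitrogen: (hydroxycarbamoyl)methyl in place of hydroxycarbamoyl on a saturated chain carbon, two bonds along the chain from an aromatic nitrogen.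

The relevant steps are an at least 5.5-fold higher number from compound 1 to compound 2 (0.74 log units; beyond the scatter) and an at least 16-fold higher number from compound 1 to compound 3 (1.22 log units; beyond the scatter), both toward weaker inhibition. The closest comparison, a step that the two limits leave unreadable from compound 2 to compound 3, gives no size. Compound 4 is therefore expected to remain weak, with no step beyond the scatter expected in this assay: the estimated step is an at least 1.2-fold lower number from compound 3 to compound 4 (0.09 log units; that floor lies within the scatter). For compound 4 the estimate is 120000 nM, with an expected range of 40000 nM to 300000 nM.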

Compound 4, half-maximal inhibitory concentration: > 150000 nM
Compound 4: no number, only a limit; the forecaster's own chance of this, stated with the estimate: 70%; at least 1.2-fold (0.09 log units) between middle value and limit.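

In this assay compound 4 has only a limit, > 150000 nM. Within the data shown here, with (hydroxycarbamoyl)methyl in place of hydroxycarbamoyl, the series stays at the limit of compound 3: the limit of > 150000 nM in this assay, at which 2 of the 4 values shown sit. The one readable new step is an at least 16-fold higher number from compound 1 to compound 4 (1.22 log units; beyond the scatter), while the steps among compound 2, compound 3 and compound 4 cannot be read, as each has limits at both ends.

The size of any difference among these three hydroxycarbamoyl compounds stays open. Also open, going by these compounds, is how a carboxylic acid at the chain end, or a longer hydroxycarbamoyl chain, would compare with compound 1.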